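Compound 3 to compound 4: a benzyl swap

This account rests on a few compounds, and the source may have more. Where it says the series, first, only, none or still open, it means among the compounds named here.

In a functional assay, read by spectrophotometry, with a stated time of 30 min (a lower number here means a stronger inhibitor, a higher number a weaker inhibitor), the three measured compounds give closely grouped values. Compound 1 (`CC(C)(C)c1cc(CCC(=O)NCCC2CCN(Cc3ccccc3)CC2)cc(C(C)(C)C)c1O`) gives 54500 nM. Compound 2 (`COc1ccc(CN2CCC(CCNC(=O)/C=C/c3cc(C(C)(C)C)c(O)c(C(C)(C)C)c3)CC2)cc1`) gives 61200 nM. Compound 3 (`Cc1ccc(CN2CCC(CCNC(=O)/C=C/c3cc(C(C)(C)C)c(O)c(C(C)(C)C)c3)CC2)cc1`) gives 60400 nM, which lies within the scatter of both other compounds, so it has no meaningful rank among them.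

Compound 4 (`CC(C)(C)c1cc(/C=C/C(=O)NCCC2CCN(Cc3cccc(F)c3)CC2)cc(C(C)(C)C)c1O`) is still unmeasured. It differs from compound 3 in one place, reading 4-methylbenzyl to 3-fluorobenzyl: 3-fluorophenyl in place of 4-methylphenyl on a saturated chain carbon bound to an amine nitrogen in a ring.

For the measured compounds named here, only one measured step bears on this change: a 1.0-fold lower number from compound 2 to compound 3 (0.01 log units; within the scatter), with methyl in place of methoxy on an aromatic carbon. That step falls on the same benzyl group and stays within the scatter. Going by the values given here, it is a single step, however, and no measured compound carries a fluorine or a 3-fluorophenyl group, so the evidence for this exact swap is indirect. With nothing pointing to a real shift, no change beyond the scatter is expected in this assay, and no direction is favoured. The expected size of the change is a 1.1-fold lower number from compound 3 to compound 4 (0.04 log units; within the scatter). For compound 4 the estimated value is 55000 nM, with an expected range of 28000 nM to 100000 nM.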

Compound 4, half-maximal inhibitory concentration: 55200 nM
Compound 4: middle estimate off by 1.0-fold (0.00 log units), on the low side; the measured number falls inside the stated range.
By their numbers in this assay, from the lowest: compounds 1, 4, 3 and 2 (each within the scatter of the next).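

Working notes, benzyl position: in this assay, 3-fluorophenyl on a saturated chain carbon bound to an amine nitrogen in a ring gives a 1.1-fold lower number from compound 3 to compound 4 (0.04 log units; within the scatter) against 4-methylphenyl, and a 1.1-fold lower number from compound 2 to compound 4 (0.04 log units; within the scatter) against 4-methoxyphenyl. The earlier step at this position compared only 4-methoxyphenyl with 4-methylphenyl, so these two steps extend the within-scatter picture to a fluorine-bearing group and to a substituent numbered differently in the group's name, across all three compounds that share this chain. No accompanying measurement bears on this result, so the flat reading stands as an observation only.

Still open, from the compounds shown here alone, is whether any group at this position moves the number beyond the scatter, for example an amine or a carboxylic acid on the phenyl ring, or a longer chain in place of the benzyl carbon. Compound 1 differs from each of the other compounds in more than one place, so the contribution of its saturated amide chain cannot be separated from that of its unsubstituted benzyl group.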